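The compounds below may be only part of what the source reports. "The series", "measured", "known", "first", "only" and "open" are said of these compounds alone.

Among the compounds with values here, compound 1 `O=C1O[C@@H](Cn2cc(Cl)nn2)CN1c1ccc(C2=CCS(=O)(=O)CC2)c(F)c1` is the only compound here with a numerical result: in an assay for binding affinity to Amine oxidase [flavin-containing] A (Homo sapiens) (a higher number here means a weaker inhibitor, a lower number a stronger inhibitor), compound 1 gives 3000 nM. Compound 2 `C[Si](C)(C)C#Cc1cn(C[C@H]2CN(c3ccc(C4=CCS(=O)(=O)CC4)c(F)c3)C(=O)O2)nn1` differs from compound 1 by a group of six heavy atoms in place of one chlorine atom on an aromatic carbon. For compound 2 this assay reports only a limit, > 200000 nM. The step of an at least 66-fold higher number from compound 1 to compound 2 (1.82 log units; beyond the scatter) is thus a clear weakening, and its size rests on the limit (the limit of > 200000 nM in this assay, at which 1 of the 2 values shown sits), so its true extent is not known.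

Compound 3 `Cc1cnnn1C[C@H]1CN(c2ccc(C3=CCS(=O)(=O)CC3)c(F)c2)C(=O)O1` carries the change (5-methyl-1H-1,2,3-triazol-1-yl in place of 4-chloro-1H-1,2,3-triazol-1-yl on a saturated chain carbon bound to a saturated ring carbon). Within the data shown here, the step from compound 1 to compound 2 is the only measured step touching the same triazole ring, and it was large. The change in compound 3 is a different replacement, with the chlorine leaving and a methyl entering at another ring carbon, so that step gives only a rough guide. A moderate weakening is expected, with the expected step of a 2.7-fold higher number from compound 1 to compound 3 (0.43 log units; beyond the scatter). The estimate for compound 3 in this assay is 8000 nM, with a range from 2000 nM to 40000 nM.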

Compound 3, inhibition constant: 4500 nM
Estimate against measurement, compound 3: 1.8-fold (0.25 log units) above; the range from low to high includes it.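

Compound 3 shows that this place can take a different triazole without a clear change in this assay: with 5-methyl-1H-1,2,3-triazol-1-yl in place of 4-chloro-1H-1,2,3-triazol-1-yl, the result is a 1.5-fold higher number from compound 1 to compound 3 (0.18 log units; within the scatter), so compounds 1 and 3 cannot be told apart. The large weakening seen earlier with compound 2 is therefore not a result of every change to the triazole, since here the chlorine leaves and a methyl enters on another ring carbon with no effect beyond the usual variation between repeated measurements. Compound 3 also gives compound 2 a second comparison, an at least 44-fold lower number from compound 2 to compound 3 (1.64 log units; beyond the scatter), which is large, but its full size stays unknown, as compound 2 gives only a limit: the limit of > 200000 nM in this assay, at which 1 of the 3 values shown sits.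

The chlorine and the methyl sit on different ring carbons, so these compounds cannot separate the effect of the group from the effect of where it sits on the triazole. From the compounds shown here alone, how an amine, a carboxylic acid or a longer chain such as propyl on this triazole would read in this assay also remains open, as does where between compound 3 and compound 2 such groups would fall.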